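This account rests on a few compounds, and the source may have more. Where it says the series, first, only, none or still open, it means among the compounds named here.

Measured so far:
Compound 1, `Cc1ccc(Nc2nc(Cl)nc3c2ncn3Cc2ccc(C(=O)Nc3ccccc3N)cc2)cc1`, in a functional assay on HCT-116 cells (Homo sapiens) for antiproliferative activity, read by CCK-8 assay, with a stated time of 72 h, tested at 2 uM (a higher number here means a stronger effect of the compound at the concentration tested, a lower number a weaker effect), gives 76.3%.
Compound 2, `CC1CCN(c2nc(Cl)nc3c2ncn3Cc2ccc(/C=C/C(=O)Nc3ccccc3N)cc2)CC1`, in this assay gives 4.24%.

Of these two numbers, compound 1 holds the higher one; compound 2 sits far enough below it that the gap is beyond the usual scatter of repeated measurements. Within the data shown here, the two compounds differ in more than one place, so no single structural step connects their values, and nothing can be read from the gap about any one change.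

Compound 3, `Nc1ccccc1NC(=O)c1ccc(Cn2cnc3c(Nc4ccc(-c5ccccn5)cc4)nc(Cl)nc32)cc1`, is not yet measured. It differs from compound 1 in one place: pyridin-2-yl in place of methyl on an aromatic carbon. Among the measured compounds shown here, no pair of measured compounds differs in only one spot, so there is no precedent from which the size of this step could be read. The shared core and the remainder of compound 1 are kept unchanged. A modest shift is the most that can be reasoned for; the expected step in this assay is a number 11.3 percentage points lower from compound 1 to compound 3 (beyond the scatter), within or only a little beyond the scatter. Compound 3 is therefore estimated at 65%, with a range from 35% to 85%.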

Compound 3, a percentage reported as inhibition, at one concentration (the size of the read-out at that concentration, not a potency): 69.5%
Estimate against measurement, compound 3: 4.5 percentage points below, within the range that was stated.
By their numbers in this assay, from the lowest: compound 2; then compounds 3 and 1 (each within the scatter of the next).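

In this assay, replacing methyl with pyridin-2-yl gives a number 6.8 percentage points lower from compound 1 to compound 3 (within the scatter), so this place, para to a large group on the aromatic ring of carbon only, accommodates far more than the small methyl group of compound 1 without a difference that can be told from the scatter. The swap takes out 1 heavy atom and brings in 6 heavy atoms, including a whole six-membered aromatic ring and a hydrogen-bond acceptor, yet the two compounds stay level on this read-out at the single concentration tested. No measurement here explains why the larger group is accommodated, so the result records the outcome without a cause.

From the compounds shown here alone, two groups at one place cannot show how far this latitude extends, and it remains open whether an amine, a carboxylic acid or a longer chain such as hexyl would fit as well as pyridin-2-yl does. Going by these compounds, since the read-out is taken at one concentration and is not a potency, it also remains open whether compound 1 and compound 3 would stay level at other concentrations.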